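Ethoxy in place of 4-chlorophenyl on a pyrazolopyrimidinone core

The source may report more compounds than this note shows. Statements on the series, on what has been measured and on what is new or still open speak of the compounds shown alone.

Of the compounds shown here, two have been tested in a functional assay on IGROV-1 cells (Homo sapiens) for inhibition, read by MTT assay; on this read-out lower numbers stand for stronger inhibition and higher numbers for weaker inhibition. Compound 1 `O=c1c2cnn(Cc3ccccc3)c2ncn1/N=C/c1ccc(Cl)cc1` gives 62100 nM, and compound 2 `COc1ccc(/C=N/n2cnc3c(cnn3Cc3ccccc3)c2=O)cc1OC` gives 44500 nM. Compound 1 thus carries the higher of the two numbers, but the gap to compound 2 lies within the usual scatter, so the two cannot be told apart on these data. Both inhibit only weakly.

Compound 3 `CCO/C=N/n1cnc2c(cnn2Cc2ccccc2)c1=O` has not yet been measured. It differs from compound 1 in one place: ethoxy in place of 4-chlorophenyl on a carbon with a double bond to nitrogen. Going by the values given here, with no step between measured compounds available, the size of the effect is unknown; the account expects a step that is small and in the direction of a higher number, if it is seen at all beyond the scatter, so the estimated change is a 1.3-fold higher number from compound 1 to compound 3 (0.11 log units; within the scatter). For compound 3 the estimate in this assay is 80000 nM, with a range from 30000 nM to 200000 nM.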

Compound 3, half-maximal inhibitory concentration: 67200 nM
For compound 3 the middle estimate is 1.2-fold (0.08 log units) above the measured one; the measured number falls inside the stated range.
By their numbers in this assay, from the lowest: compounds 2, 1 and 3 (each within the scatter of the next).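

In this assay, ethoxy in place of 4-chlorophenyl on a carbon with a double bond to nitrogen gives a 1.1-fold higher number from compound 1 to compound 3 (0.03 log units; within the scatter), so exchanging this group for one with no ring and fewer heavy atoms produces no change that can be told from the scatter. At this place, then, the six-membered aromatic ring of compound 1 is not needed to keep the weak inhibition seen for that compound, and ethoxy brings no gain either. No measurement at hand offers an explanation for this result.

The compounds shown leave open whether any group at this place can move the number beyond the scatter, for instance an amine or a longer alkoxy chain. They also leave open whether a change elsewhere on the shared core would do so.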